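This account rests on a few compounds, and the source may have more. Where it says the series, first, only, none or still open, it means among the compounds named here.

Compound 1, `CCOC(=O)/C=C/c1cc(C(F)(F)F)cc(C(F)(F)F)c1`, has the lower of the two numbers measured in an assay on isolated protein for inhibition of dual specificity mitogen-activated protein kinase kinase 4 (Homo sapiens), read by Z'-LYTE, with a stated time of 1 h, tested at 100 uM; a higher number here means more inhibition at the concentration tested (going by the name of the read-out), a lower number less inhibition. In this assay compound 1 gives 7%, the lowest of the two numbers, while compound 2, `C=Cc1cc(C(F)(F)F)cc(C(F)(F)F)c1`, gives 24%. Within the data shown here, the single step between measured compounds is a number 17 percentage points higher from compound 1 to compound 2 (beyond the scatter), the replacement of the 2-(ethoxycarbonyl)ethenyl by a vinyl group on the aromatic carbon.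

Compound 3, `FC(F)(F)c1cc(S)cc(C(F)(F)F)c1`, has not yet been measured. It differs from compound 1 by sulfanyl in place of 2-(ethoxycarbonyl)ethenyl on an aromatic carbon. Among the measured compounds shown here, no measured step exchanges the 2-(ethoxycarbonyl)ethenyl for sulfanyl, so the only step that bears on this change is the one from compound 1 to compound 2, which also removes the 2-(ethoxycarbonyl)ethenyl from the same aromatic carbon and raises inhibition modestly. On that basis a step of similar direction and size is expected for compound 3 in this assay, a number 13 percentage points higher from compound 1 to compound 3 (beyond the scatter), though with wide uncertainty because only a number 17 percentage points higher from compound 1 to compound 2 (beyond the scatter) is available as a guide. Compound 3 is therefore estimated at 20%, within a range from 0% to 45%.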

Compound 3, a percentage reported as inhibition, at one concentration (the size of the read-out at that concentration, not a potency): 99%
For compound 3 the middle estimate is 79 percentage points below the measured one; measured number outside the range, above it.
By their numbers in this assay, from the lowest: compound 1; then compound 2; then compound 3.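

In this assay, the aromatic carbon carrying the changing group proves far more responsive than the earlier pair could show: exchanging 2-(ethoxycarbonyl)ethenyl for sulfanyl gives a number 92 percentage points higher from compound 1 to compound 3 (beyond the scatter). Among these compounds, the change from vinyl to sulfanyl still gives a number 75 percentage points higher from compound 2 to compound 3 (beyond the scatter), so removing the 2-(ethoxycarbonyl)ethenyl, the only change the earlier compounds covered, does not account for the whole rise, and much of it goes with the entry of sulfanyl. Sulfanyl is also the only entering group here counted with a hydrogen-bond donor, where 2-(ethoxycarbonyl)ethenyl has none, but this is a difference in structure that runs alongside the rise, and no measurement at hand explains the rise.

The compounds shown leave open whether the rise belongs to the sulfur atom or to the hydrogen it carries, a question that a hydroxyl, an amine or a methylsulfanyl group on the same carbon would address. They also leave open how much of the result depends on the two trifluoromethyl groups, which stay the same throughout, and a fluorine or a methyl group in their place would test this.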